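The source may hold more compounds than are shown below. What is called first, only, known or untested is meant among the compounds shown, and "the series" means these compounds.

Measured compounds:
- compound 1, `Fc1ccc(C2CC(c3ccccc3)=NN2c2ccc(-c3ccccc3)nn2)cc1`: 89200 nM
- compound 2, `Clc1ccc(C2=NN(c3ccc(-c4ccccc4)nn3)C(c3ccccc3)C2)cc1`: 96700 nM
- compound 3, `Clc1ccc(C2=NN(c3ccc(-c4ccccc4)nn3)C(c3ccc(Cl)cc3)C2)cc1`: > 100000 nM

The three compounds share one core and differ only in the substitution of the pendant phenyl rings. In a functional assay on A549 cells (Homo sapiens) for antiproliferative activity, read by MTT assay, with a stated time of 24 h (on this read-out higher numbers stand for weaker inhibition and lower numbers for stronger inhibition), compound 1 gives 89200 nM. In this assay compound 2 gives 96700 nM. For compound 3 this assay reports only a limit, > 100000 nM, so compound 3 sits at the limit of > 100000 nM in this assay, at which 1 of the 3 values shown sits, with no number to place it among the others. Going by the values given here, the one single-point step that is known, an at least 1.0-fold higher number from compound 2 to compound 3 (0.01 log units; that floor lies within the scatter), is small and lies within the scatter.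

Compound 4, `Fc1ccc(C2CC(c3ccc(Cl)cc3)=NN2c2ccc(-c3ccccc3)nn2)cc1`, is still to be measured in this assay. It differs from compound 3 by fluoro in place of chloro on an aromatic carbon. Among the compounds with values here, no measured step matches this change; the only halogen step known, from compound 2 to compound 3, adds chloro and lies within the scatter, and compounds 1 and 2, which carry fluoro and chloro on different rings, show values within the scatter of each other. Compound 4 is therefore expected to show a number no higher from compound 3 to compound 4 (the limit leaves the size open), i.e. no step beyond the scatter. The expected value for compound 4 is 100000 nM, in the range 50000 nM to 200000 nM, with a fair chance that this assay again returns only a limit.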

Compound 4, half-maximal inhibitory concentration: > 100000 nM
Compound 4: a limit, no number (the forecaster's own chance of this, stated with the estimate: 55%); the middle value lies on the limit itself.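

Like compound 3, compound 4 returns only a limit in this assay, > 100000 nM, so the swap of 4-chlorophenyl to 4-fluorophenyl cannot be read as a step; the new result shows only that fluoro at this place, like chloro, ends at a limit. The two steps that can be read, an at least 1.0-fold higher number from compound 2 to compound 4 (0.01 log units; that floor lies within the scatter) and an at least 1.1-fold higher number from compound 1 to compound 4 (0.04 log units; that floor lies within the scatter), are floors only. Adding a halogen to the second phenyl ring therefore gives the same open reading in both comparisons: the same change on two cores in this assay, an at least 1.0-fold higher number (0.01 log units; that floor lies within the scatter) from compound 2 to compound 3 and an at least 1.1-fold higher number (0.04 log units; that floor lies within the scatter) from compound 1 to compound 4; the limit leaves it open whether they differ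

On these data alone, how far compound 3 and compound 4 really lie past the limit stays open, and the values now gather there: the limit of > 100000 nM in this assay, at which 2 of the 4 values shown sit. Also open is whether an amine or a carboxylic acid at this place would give a measurable number in this assay.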